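The compounds below may be only part of what the source reports. "The series", "measured", "known", "first", "only" and "open" are said of these compounds alone.

The measured compounds:

Compound 1, `CC(=O)N1CCN(S(=O)(=O)c2ccc(F)cc2)C(CO)C1`, gives 1 mg/kg in a functional assay on the whole organism (strain CD-1) with Mus musculus as the target, with a stated time of 20 min; a lower number here means that less compound is needed, a higher number that more compound is needed for the effect.
Compound 2, `CC(=O)N1CCN(S(=O)(=O)c2ccc(F)cc2)CC1CO`, gives 10 mg/kg in this assay.
Compound 3, `COCC1CN(C(C)=O)CCN1S(=O)(=O)c1ccc(F)cc1`, gives 1 mg/kg in this assay.

Compound 1 and compound 3 share a core and differ only by methyl in place of hydrogen on an oxygen on a saturated carbon; the step in this assay from compound 1 to compound 3 is no change at the digits printed from compound 1 to compound 3 (within the scatter), so this change left the dose unaltered within the scatter. Compound 2 has the same atoms as compound 1 joined differently, and the difference between the two cores is not broken down here; compound 2 needs the highest dose of the three, beyond the scatter from both compound 1 and compound 3.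

Compound 4, `COCC1CN(S(=O)(=O)c2ccc(F)cc2)CCN1C(C)=O`, is not yet measured. It differs from compound 2 by methyl in place of hydrogen on an oxygen on a saturated carbon, the same change as from compound 1 to compound 3, at the same kind of place. Because the earlier step was no change at the digits printed from compound 1 to compound 3 (within the scatter), the step from compound 2 to compound 4 is expected to be about no change at the digits printed from compound 2 to compound 4 (within the scatter). Compound 4 is therefore estimated at 10 mg/kg, with a range from 3 mg/kg to 30 mg/kg.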

Compound 4, minimum effective dose in the Mus musculus assay: > 10 mg/kg
Compound 4 was reported as a limit (the forecaster's own chance of this, stated with the estimate: 5%); the middle value lies on the limit itself.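

In the Mus musculus assay the change from hydroxymethyl to methoxymethyl gave a number no lower from compound 2 to compound 4 (the limit leaves the size open) and the value of compound 4 stands as a limit of the assay, not a number. Set beside the earlier step, the change reads as follows: the same change on two cores in the Mus musculus assay, no change at the digits printed (within the scatter) from compound 1 to compound 3 and a number no lower (the limit leaves the size open) from compound 2 to compound 4; the limit leaves it open whether they differ

Among the compounds shown here, this shows only that the change did not lower the number on the core of compound 2; it does not show whether the step there matches the one on the core of compound 1 in size.

In a physicochemical assay for metabolic stability, read by LC-MS, in phosphate buffer, tested at 1 uM (on this read-out higher numbers stand for a longer-lived compound and lower numbers for a shorter-lived compound), compound 2 gives >= 4 h as a limit of the assay. In the physicochemical assay compound 4 gives >= 4 h as a limit too, and the step in this assay cannot be read.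

Going by these compounds, the size of the step on the core of compound 2 remains open. Also open, on these data alone, is whether a longer chain on that oxygen, or an amine or a carboxylic acid in place of the hydroxy group, would behave alike on both cores.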